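A Chloro Group Tried Where Methyl Did Little

The source may hold more compounds than are shown below. What is called first, only, known or untested is meant among the compounds shown, and "the series" means these compounds.

Compound 1 `O=c1[nH]nc2n(c1=O)CCN2c1ccccc1` is the starting point. In a functional assay on T47D cells (Homo sapiens) for cytotoxicity, with a stated time of 72 h, tested at 10 ug/mL (on this read-out lower numbers stand for a weaker effect and higher numbers for a stronger effect at the one concentration tested), compound 1 gives 0%, and it stands level with compound 3 `Cc1ccccc1N1CCn2c1n[nH]c(=O)c2=O`, which gives 0%; together these two are the lowest of the three numbers. Furthest from compound 1 stands compound 2 `Cc1ccc(N2CCn3c2n[nH]c(=O)c3=O)cc1`, which gives 14%.

Compound 4 `O=c1[nH]nc2n(c1=O)CCN2c1cccc(Cl)c1` has not yet been measured. It differs from compound 1 by chloro in place of hydrogen on an aromatic carbon.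

Among the compounds with values here, two measured steps bear on this change, each a methyl in place of hydrogen on an aromatic carbon of the same ring. One is a number 14 percentage points higher from compound 1 to compound 2 (beyond the scatter). The other is no change at the digits printed from compound 1 to compound 3 (within the scatter). A single small group on this ring therefore gave at most a modest rise, and in one case nothing beyond the scatter. Within the data shown here, no measured step involves chloro, so its own effect is unknown here.

On this basis only a small shift is expected: a number 6 percentage points higher from compound 1 to compound 4 (within the scatter). The estimate for compound 4 is 6%, with a range from 0% to 20%.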

Compound 4, a percentage reported as inhibition, at one concentration (the size of the read-out at that concentration, not a potency): 0%
Beside the measured number, compound 4's estimate is 6 percentage points above it; low and high end bracket the measured number.
By their numbers in this assay, from the lowest: compounds 1, 3 and 4 (each within the scatter of the next); then compound 2.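

In this assay, chloro in place of hydrogen on an aromatic carbon, meta to a large group, gives no change at the digits printed from compound 1 to compound 4 (within the scatter) and so adds a first result for a group other than methyl on this ring. Within the data shown here, with the methyl change that gives no change at the digits printed from compound 1 to compound 3 (within the scatter), two of the three single changes on this ring now stay within the scatter, and the only step beyond it remains a number 14 percentage points higher from compound 1 to compound 2 (beyond the scatter) for the methyl of compound 2. Nothing shown gives a reason for this outcome.

On these data alone, whether chloro elsewhere on the ring, or a different group such as an amine or a carboxylic acid, would change the number remains open. Also open, as far as these compounds go, is whether a second group added to the ring of compound 2 would raise the number further.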